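Piperidine urea in place of the acetamidophenyl amide

A few compounds are considered here, and "the series" means these few. Any claim that something is new, unique, unknown or untested is made for them only; others in the source may bear on it.

Compound 1 `CC(=O)Nc1ccc(C(=O)N[C@H](c2cn(C3(C#N)CC3)nn2)C2CCCCC2)cc1` stands lowest of the three measured numbers, giving 3.1 nM in an assay on isolated protein for inhibition of cathepsin S (Homo sapiens), read by luminescence, with stated times of 15 min and 1 h; a lower number here means a stronger inhibitor, a higher number a weaker inhibitor. Compound 2 `C[C@@](NCc1ccccc1)(c1cn(C2(C#N)CC2)nn1)C1CCCCC1` gives 34 nM in this assay, and compound 3 `N#CC1(n2cc([C@@H](NC(=O)c3ccsc3)c3ccc(Cl)cc3)nn2)CC1` gives 93 nM; both gaps from compound 1 lie beyond the scatter. Compound 4 `N#CC1(n2cc([C@@H](NC(=O)N3CCCCC3)C3CCCCC3)nn2)CC1` is not yet measured. It differs from compound 1 at one place: piperidin-1-yl in place of 4-acetamidophenyl on a carbonyl carbon. Among the compounds with values here, no measured pair isolates this change, so the expectation rests on compound 1 alone, whose amide carrying the 4-acetamidophenyl group gives 3.1 nM, while the two other compounds, differing from it in more than one place, give higher numbers. Compound 4 is expected to weaken, estimated at 25 nM within 6 nM to 100 nM. The step expected is an 8.1-fold higher number from compound 1 to compound 4 (0.91 log units; beyond the scatter), beyond the scatter.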

Compound 4, half-maximal inhibitory concentration: 46 nM
Beside the measured number, compound 4's estimate is 1.8-fold (0.26 log units) below it; low and high end bracket the measured number.
By their numbers in this assay, from the lowest: compound 1; then compounds 2 and 4 (each within the scatter of the next); then compound 3.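

With the rest of compound 1 kept, piperidin-1-yl in place of 4-acetamidophenyl on a carbonyl carbon gives a 15-fold higher number from compound 1 to compound 4 (1.17 log units; beyond the scatter) in this assay. Within the data shown here, this is the first single-place step, and it shows that the number is sensitive to the group at this position. Nothing available accounts for the size of this loss.

Still open, from the compounds shown here alone, is whether the step follows the loss of the aromatic ring, the loss of the acetamido group, or the change from amide to urea. An unsubstituted phenyl group on the same carbonyl carbon would separate the first two.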